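From Fluoro to Trifluoromethyl on the Hydrazone Ring

A few compounds are considered here, and "the series" means these few. Any claim that something is new, unique, unknown or untested is made for them only; others in the source may bear on it.

Measured compounds:
compound 1, `CN(C(=O)NC(=O)c1cccc(C(F)(F)F)c1)c1nc(C(F)(F)F)c(C(=O)N/N=C/c2ccc(C(F)(F)F)cc2)s1`: 7.71 ug/mL
compound 2, `CN(C(=O)NC(=O)c1ccc(C(F)(F)F)cc1)c1nc(C(F)(F)F)c(C(=O)N/N=C/c2cccc(C(F)(F)F)c2)s1`: 7.95 ug/mL
compound 3, `Cc1nc(N(C)C(=O)NC(=O)c2c(F)cccc2F)sc1C(=O)N/N=C/c1ccccc1F`: > 100 ug/mL

Three compounds were tested in a functional assay on HepG2 cells (Homo sapiens) for inhibition, read by MTT assay, with a stated time of 72 h; on this read-out lower numbers stand for stronger inhibition and higher numbers for weaker inhibition. Compound 1 gives 7.71 ug/mL and compound 2 gives 7.95 ug/mL, two values that lie within the scatter of each other. Compound 3 is a different case: its result in this assay is a limit of the assay and not a number, (the limit of > 100 ug/mL in this assay, at which 1 of the 3 values shown sits), so compound 3 stands at the weak end of what was shown, with no figure of its own.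

The next compound, compound 4, `Cc1nc(N(C)C(=O)NC(=O)c2c(F)cccc2F)sc1C(=O)N/N=C/c1ccccc1C(F)(F)F`, differs from compound 3 in one place: trifluoromethyl in place of fluoro on an aromatic carbon, ortho to a large group. Going by the values given here, no step between measured compounds is available to calibrate this change, so the expectation rests on the standing of compound 3 alone.

Compound 4 is therefore expected to remain weak in this assay, close to where compound 3 sits, with an estimated value of 70 ug/mL, between 25 ug/mL and 200 ug/mL. The step that this estimate implies, an at least 1.4-fold lower number from compound 3 to compound 4 (0.15 log units; that floor lies within the scatter), is expected to be small, and a second limit rather than a number is a real possibility.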

Compound 4, half-maximal inhibitory concentration: 1.11 ug/mL
Compound 4: the middle estimate sits 63-fold (1.80 log units) above what was measured; the measured number lies below the stated range.
By their numbers in this assay, from the lowest: compound 4; then compounds 1 and 2 (each within the scatter of the next). At a limit, above all of these: compound 3.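

In this assay, the change from 2-fluorophenyl to 2-(trifluoromethyl)phenyl gives an at least 90-fold lower number from compound 3 to compound 4 (1.95 log units; beyond the scatter), the first one-place step available among these compounds, and it shows that this single position, on an aromatic carbon and ortho to a large group, can move the result far beyond the scatter. The result for compound 3 is a limit of the assay and not a number: the limit of > 100 ug/mL in this assay, at which 1 of the 4 values shown sits. On these data alone, the true size of the step therefore stays unknown, and the printed figure is only a floor.

The compounds shown do not tell how a chlorine, a methyl group or an amine at this same position would compare with trifluoromethyl. They also leave open whether the same change would give a step of similar size on another background, such as that of compound 1.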